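A methoxypyridine replaces the thiophene on the shared core

The source may hold more compounds than are shown below. What is called first, only, known or untested is meant among the compounds shown, and "the series" means these compounds.

Compound 1 `CCCCNc1nc(N)nc2ccn(Cc3ccccc3)c12`, compound 2 `CCCCNc1nc(N)nc2ccn(Cc3ccsc3)c12` and compound 3 `CCCCNc1nc(N)nc2ccn(Cc3ccc4ccccc4n3)c12` share one core and differ only in the group on a saturated chain carbon bound to an aromatic nitrogen. In an assay on HEK293 cells for agonist activity at Toll-like receptor 8 (Homo sapiens), read by a luciferase reporter, with a stated time of 6 h (on this read-out higher numbers stand for an effect only at larger amounts of compound and lower numbers for an effect already at smaller amounts), compound 1 gives only the limit > 25 uM. Compound 2 likewise gives only the limit > 25 uM in this assay. Compound 3 also reaches only the limit > 25 uM. The step that the two limits leave unreadable from compound 1 to compound 2 therefore cannot be read. Compound 4 `CCCCNc1nc(N)nc2ccn(Cc3ncccc3OC)c12` differs from compound 2 by 3-methoxypyridin-2-yl in place of thiophen-3-yl on a saturated chain carbon bound to an aromatic nitrogen. Within the data shown here, no measured step bears on this change, since every value sits at the limit (the limit of > 25 uM in this assay, at which 3 of the 3 values shown sit). Compound 4 is therefore expected to show 25 uM, between 5 uM and 60 uM, with the step of a number no higher from compound 2 to compound 4 (the limit leaves the size open) expected to stay within the scatter.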

Compound 4, minimum effective concentration: 0.59 uM
For compound 4 the middle estimate is 42-fold (1.63 log units) above the measured one, and the stated range ends above it.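

In this assay, among these compounds, the group on a saturated chain carbon bound to an aromatic nitrogen can clearly move the read-out, which the earlier compounds, all sitting at a limit, could not show. Bringing in 3-methoxypyridin-2-yl gives an at least 42-fold lower number from compound 2 to compound 4 (1.62 log units; beyond the scatter) and an at least 42-fold lower number from compound 1 to compound 4 (1.62 log units; beyond the scatter), and both steps are large. Compound 4 is the only one here with a readable number: the limit of > 25 uM in this assay, at which 3 of the 4 values shown sit.

From the compounds shown here alone, what stays open is whether the methoxy group or the ring nitrogen carries these steps. A pyridin-2-yl without the methoxy, or a 3-methoxyphenyl, would separate the two.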